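Thiourea sulfonamide series: aniline swap on the shared core

The compounds below may be only part of what the source reports. "The series", "measured", "known", "first", "only" and "open" are said of these compounds alone.

Compound 2 `NS(=O)(=O)c1ccc(NC(=S)Nc2ccc3ncnc(Nc4cccc(Cl)c4)c3c2)cc1` carries the highest number of the two measured here: in a functional assay on NCI-H1975 cells (Homo sapiens) for antiproliferative activity, read by MTT assay, with a stated time of 72 h (a lower number here means a stronger inhibitor, a higher number a weaker inhibitor), compound 2 gives 39800 nM, while compound 1 `NS(=O)(=O)c1ccc(NC(=S)Nc2ccc3ncnc(Nc4cccc(Br)c4)c3c2)cc1` gives 11000 nM. Going by the values given here, the only measured step, a 3.6-fold higher number from compound 1 to compound 2 (0.56 log units; beyond the scatter), concerns chloro in place of bromo on an aromatic carbon and is modest but beyond the scatter.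

Compound 3 `CCc1ccc(Nc2ncnc3ccc(NC(=S)Nc4ccc(S(N)(=O)=O)cc4)cc23)cc1` changes the same part of the molecule further: 4-ethylphenyl in place of 3-chlorophenyl on a nitrogen on an aromatic ring. Among the compounds with values here, no measured step swaps a halogen for an ethyl group or moves the substituent around the ring, so the earlier step bears on it only in showing that this aniline tolerates small changes with modest shifts. A step of about that size, in either direction, or none beyond the scatter is expected in this assay; the estimate for compound 3 is 30000 nM, with a range of 8000 nM to 120000 nM, corresponding to an expected step of a 1.3-fold lower number from compound 2 to compound 3 (0.12 log units; within the scatter).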

Compound 3, half-maximal inhibitory concentration: 38700 nM
The estimate for compound 3 lay 1.3-fold (0.11 log units) below the measured number; low and high end bracket the measured number.
By their numbers in this assay, from the lowest: compound 1; then compounds 3 and 2 (each within the scatter of the next).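

In this assay, 4-ethylphenyl in place of 3-chlorophenyl on a nitrogen on an aromatic ring gives a 1.0-fold lower number from compound 2 to compound 3 (0.01 log units; within the scatter) and so separates the two compounds by no more than the scatter, even though the halogen is gone and the substituent's ring position differs. The same group in place of 3-bromophenyl gives a 3.5-fold higher number from compound 1 to compound 3 (0.55 log units; beyond the scatter) and this step lies beyond the scatter, leaving compound 1 as the only one of the three set apart from both others. No measured evidence accounts for these values.

Because the group and its ring position change together between compound 2 and compound 3, their separate contributions cannot be read from these compounds. On these data alone, whether 3-ethylphenyl, 4-chlorophenyl or a phenyl ring bearing an amine or a carboxylic acid would leave the number unchanged remains open.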